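Two Inactive Analogues and a Bromophenyl Exchange

The compounds below may be only part of what the source reports. "The series", "measured", "known", "first", "only" and "open" are said of these compounds alone.

Compound 1, `N#CC1=C(N)Oc2c(c3nc4ccccc4nc3c3ccccc23)C12C(=O)N(Cc1cnnn1-c1cc(Cl)ccc1Cl)c1ccccc12`, in an ADME assay on L02 cells (Homo sapiens) for antiproliferative activity, read by MTT assay, with a stated time of 48 h (on this read-out lower numbers stand for stronger inhibition and higher numbers for weaker inhibition), gives only a limit, > 50000 nM.
Compound 2, `Cc1ccccc1-n1nncc1CN1C(=O)C2(C(C#N)=C(N)Oc3c(N)cc4nc5ccccc5nc4c32)c2ccccc21`, in this assay also gives only a limit, > 50000 nM.

Going by the values given here, both measured compounds therefore sit at the limit of > 50000 nM in this assay, at which 2 of the 2 values shown sit, and neither can be placed above or below the other: compound 2 stands at the same limit as compound 1, and no step between measured compounds can be drawn from these two readings. Nothing in the numbers separates compound 2 from its companion.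

Compound 3, `N#CC1=C(N)Oc2c(N)cc3nc4ccccc4nc3c2C12C(=O)N(Cc1cnnn1-c1cccc(Br)c1)c1ccccc12`, is a close relative of compound 2. Among the compounds with values here, the only change is 3-bromophenyl in place of 2-methylphenyl on an aromatic nitrogen. Within the data shown here, no measured pair shows what such an exchange does in this assay, so the expectation rests on compound 2 alone, whose reading in this assay is a limit, > 50000 nM. With the neighbouring compound unable to produce a number, the step from compound 2 to compound 3 is expected to be a number no higher from compound 2 to compound 3 (the limit leaves the size open), that is, none beyond the scatter. Compound 3 is thus expected to read 50000 nM in this assay, within a range from 15000 nM to 200000 nM.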

Compound 3, half-maximal inhibitory concentration: > 50000 nM
Compound 3: no number, only a limit (the forecaster's own chance of this, stated with the estimate: 80%); the middle value lies on the limit itself.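

In this assay compound 3 gives only a limit, > 50000 nM. Compound 2 gives a limit too, so no step can be read between compound 2 and compound 3, and all the compounds shown stand together: the limit of > 50000 nM in this assay, at which 3 of the 3 values shown sit.

The compounds shown leave open whether 3-bromophenyl in place of 2-methylphenyl on an aromatic nitrogen changes the reading at all.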